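The compounds below may be only part of what the source reports. "The series", "measured", "known", "first", "only" and "open" are said of these compounds alone.

Measured so far in a functional assay on the whole organism (strain Wistar) for inhibition, with Rattus norvegicus as the target, read by paw edema, in the formalin test, with a stated time of 6 h; a higher number here means that more compound is needed for the effect, a lower number that less compound is needed:
- compound 1 `O=C(Nc1nc2ccccc2[nH]1)c1cc2ccccc2oc1=O`: 1200000 nM
- compound 2 `COc1ccc2oc(=O)c(C(=O)Nc3nc4ccccc4[nH]3)cc2c1`: 28500000 nM

Of these two, compound 2 carries the higher number at 28500000 nM, so more of it is needed for the effect. Within the data shown here, the gap to its only measured neighbour is large and beyond the usual scatter of this kind of measurement.

The next compound, compound 3 `O=C(Nc1nc2ccccc2[nH]1)c1cc2cc(Br)ccc2oc1=O`, keeps the shared core and changes one group: bromo in place of methoxy on an aromatic carbon.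

Among the measured compounds shown here, only one measured step bears on this carbon, the change of hydrogen to methoxy, which was a 24-fold higher number from compound 1 to compound 2 (1.38 log units; beyond the scatter). For the measured compounds named here, compound 3 loses that methoxy, but no bromo compound has been measured, so the data cannot say how closely bromo will resemble hydrogen. With a single step to go on, part of that large rise is expected to be undone, though not all of it. The estimated change is a 5.7-fold lower number from compound 2 to compound 3 (0.76 log units; beyond the scatter), towards a lower number.

For compound 3 the estimate is 5000000 nM, with an expected range of 700000 nM to 30000000 nM.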

Compound 3, half-maximal effective concentration: 1900000 nM
Estimate against measurement, compound 3: 2.6-fold (0.42 log units) above; measured number inside the range.
By their numbers in this assay, from the lowest: compounds 1 and 3 (each within the scatter of the next); then compound 2.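

In this assay, putting bromo in place of the methoxy gives a 15-fold lower number from compound 2 to compound 3 (1.18 log units; beyond the scatter) and so shows that the large rise seen with methoxy on this aromatic carbon does not come with every group placed there. Set against hydrogen on the same carbon, bromo gives a 1.6-fold higher number from compound 1 to compound 3 (0.20 log units; within the scatter) and therefore cannot be told apart from hydrogen in this measurement, which leaves methoxy as the one group of these three that stands apart. Nothing available here explains why methoxy differs from the other two groups, so the numbers describe the change but give no reason for it.

From the compounds shown here alone, with only hydrogen, methoxy and bromo to compare on this carbon, it remains open whether the high number belongs to methoxy alone or would also appear with a longer chain such as ethoxy, with an amine or with a carboxylic acid. These compounds also leave open whether bromo or methoxy on another carbon of the same ring would give the same numbers as on this one.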